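A few compounds are considered here, and "the series" means these few. Any claim that something is new, unique, unknown or untested is made for them only; others in the source may bear on it.

For the measured compounds named here, compound 3 `Cc1cc(Nc2nc(NCc3ccc(F)cc3F)nc3ccccc23)n[nH]1` gives 200 nM in an assay for inhibition of high affinity nerve growth factor receptor (Homo sapiens), read by HTRF, with a stated time of 30 min, in the presence of a further agent that is not named here (a lower number here means a stronger inhibitor, a higher number a weaker inhibitor), and stands highest of the three numbers measured so far. Compound 1 `Cc1cc(Nc2nc(NCc3ccc(Br)cc3)nc3ccccc23)n[nH]1` gives 180 nM in this assay, and compound 2 `Cc1cc(Nc2nc(NCc3ccc(C#N)cc3)nc3ccccc23)n[nH]1` gives 83 nM. The gap between them is a 1.1-fold higher number from compound 1 to compound 3 (0.05 log units; within the scatter), while a 2.4-fold higher number from compound 2 to compound 3 (0.38 log units; beyond the scatter) and a 2.2-fold lower number from compound 1 to compound 2 (0.34 log units; beyond the scatter) are the two steps that clear the scatter.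

Compound 4 `Cc1cc(Nc2nc(NCc3cc(F)ccc3F)nc3ccccc23)n[nH]1` differs from compound 3 only by 2,5-difluorophenyl in place of 2,4-difluorophenyl on a saturated chain carbon bound to a nitrogen on an aromatic ring. The measured steps that touch the same place, a 1.1-fold higher number from compound 1 to compound 3 (0.05 log units; within the scatter) and a 2.4-fold higher number from compound 2 to compound 3 (0.38 log units; beyond the scatter), both exchange the whole group on that saturated chain carbon rather than move a fluorine from one ring position to another, and the first of them did not leave the scatter. Going by the values given here, no measured pair shows what a shift of one fluorine within the phenyl ring does, so the expectation rests on the group staying the same size and make-up.

Compound 4 is therefore estimated at 200 nM, with a range from 90 nM to 450 nM. The estimated step, no change at the digits printed from compound 3 to compound 4 (within the scatter), is expected to remain within the scatter in either direction.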

Compound 4, half-maximal inhibitory concentration: 7.5 nM
The estimate for compound 4 lay 27-fold (1.43 log units) above the measured number; the whole stated range lies above it.
By their numbers in this assay, from the lowest: compound 4; then compound 2; then compounds 1 and 3 (each within the scatter of the next).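

In this assay, for the compounds shown here, the arrangement of the two fluorines alone carries a large effect: with the same atoms in the same group, the change to 2,5-difluorophenyl on a saturated chain carbon bound to a nitrogen on an aromatic ring gives a 27-fold lower number from compound 3 to compound 4 (1.43 log units; beyond the scatter), whereas the earlier steps at this place were modest or lay within the scatter. Going by these compounds alone, the same group also sets compound 4 clearly apart from the other two compounds, with an 11-fold lower number from compound 2 to compound 4 (1.04 log units; beyond the scatter) and a 24-fold lower number from compound 1 to compound 4 (1.38 log units; beyond the scatter), so the place is far more sensitive to the ring pattern than the earlier compounds suggested. Nothing available bears on the reason for this result.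

Going by these compounds, whether both fluorines are needed remains open, as does whether a chlorine, a methoxy group or an amine could stand in for either one. Also open, on these data alone, is whether the gain survives a longer chain between the ring and the nitrogen.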